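Thiophene for dimethylphenyl on a chlorobenzoyl vinyl sulfone core

The source may report more compounds than this note shows. Statements on the series, on what has been measured and on what is new or still open speak of the compounds shown alone.

Measured compounds:
compound 1 `Cc1ccc(CS(=O)(=O)/C(=C/c2sccc2C)C(=O)c2ccc(Cl)cc2)cc1` — 25000 nM
compound 2 `Cc1ccc(CS(=O)(=O)/C(=C/c2cc(C)ccc2C)C(=O)c2ccc(Cl)cc2)cc1` — 1000 nM
compound 3 `Cc1ccc(C)c(/C=C(\C(=O)c2ccc(Cl)cc2)S(=O)(=O)Cc2ccc(Cl)cc2)c1` — 10000 nM

Of the compounds shown here, three have been tested in a functional assay on DU-145 cells (Homo sapiens) for inhibition, read by trypan blue exclusion, with a stated time of 96 h; on this read-out lower numbers stand for stronger inhibition of growth and higher numbers for weaker inhibition of growth. Compound 2 gives 1000 nM and has the lowest number of the three. Compound 1 differs from compound 2 by 3-methylthiophen-2-yl in place of 2,5-dimethylphenyl on a double-bonded chain carbon bound to a double-bonded chain carbon, and this change gives a 25-fold higher number from compound 2 to compound 1 (1.40 log units; beyond the scatter). Compound 3 differs from compound 2 by chloro in place of methyl on an aromatic carbon, with a 10-fold higher number from compound 2 to compound 3 (1.00 log units; beyond the scatter). Compound 3 thus stands second highest of the three numbers.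

Compound 4 `Cc1ccsc1/C=C(\C(=O)c1ccc(Cl)cc1)S(=O)(=O)Cc1ccc(Cl)cc1` is not yet measured in this assay. It differs from compound 3 by 3-methylthiophen-2-yl in place of 2,5-dimethylphenyl on a double-bonded chain carbon bound to a double-bonded chain carbon, which is the same change as that from compound 2 to compound 1, made here on the core that carries the 4-chlorobenzyl group rather than the 4-methylbenzyl group. Because compound 3 already gives 10000 nM, and because the same change gave a 25-fold higher number from compound 2 to compound 1 (1.40 log units; beyond the scatter), compound 4 is expected to give a high number in this assay, with a 15-fold higher number from compound 3 to compound 4 (1.18 log units; beyond the scatter). The estimate for compound 4 is 150000 nM, expected to lie between 40000 nM and 500000 nM.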

Compound 4, concentration for 50% growth inhibition: 25000 nM
Beside the measured number, compound 4's estimate is 6.0-fold (0.78 log units) above it; the whole stated range lies above it.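

In this assay the change to 3-methylthiophen-2-yl in place of 2,5-dimethylphenyl gives a 2.5-fold higher number from compound 3 to compound 4 (0.40 log units; beyond the scatter), so the direction of the step holds on the second core while its size does not: the same change on two cores in this assay, a 25-fold higher number (1.40 log units; beyond the scatter) from compound 2 to compound 1 and a 2.5-fold higher number (0.40 log units; beyond the scatter) from compound 3 to compound 4, 10-fold (1.00 log units) apart, beyond the scatter of two such steps.

The exchange of methyl for chloro likewise does not carry over unchanged, since it gives no change at the digits printed from compound 1 to compound 4 (within the scatter) once 3-methylthiophen-2-yl is present: the same change on two cores in this assay, a 10-fold higher number (1.00 log units; beyond the scatter) from compound 2 to compound 3 and no change at the digits printed (within the scatter) from compound 1 to compound 4, 10-fold (1.00 log units) apart, beyond the scatter of two such steps.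

Going by these compounds alone, the four compounds thus show that the two changes do not add up independently here, and that the size of a step on one core cannot simply be applied to another; they do not show what underlies this, and with only two cores they establish no rule for the wider series.

On these data alone, it remains open whether the same dependence would appear with other groups on the double-bonded chain carbon. As far as these compounds go, it is also open how a carboxylic acid or an amine in place of the chloro or methyl group would behave with either 2,5-dimethylphenyl or 3-methylthiophen-2-yl present.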